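Indole for Oxadiazolylphenyl: Cytotoxicity Outlook in HEK293 Cells

This account rests on a few compounds, and the source may have more. Where it says the series, first, only, none or still open, it means among the compounds named here.

Compound 1, `CCOC(=O)CCCCCOc1cccc(CN(C(=O)c2ccccc2)C(C)C)c1`, in an ADME assay on HEK293 cells (Homo sapiens) for cytotoxicity, read by CellTiter-Glo and resazurin assay, with a stated time of 72 h (a lower number here means that less compound is needed, a higher number that more compound is needed for the effect), gives only the assay limit > 26000 nM. Compound 2, `CCOC(=O)CCCCCOc1cccc(CN(C(=O)c2ccc(-c3cccc(-c4nnc(C)o4)c3)cc2)C(C)C)c1`, gives only the assay limit > 26000 nM in this assay.

For the measured compounds named here, compound 2 thus stands at a limit rather than at a number, and the one further value shown for this series is likewise a limit, as the limit of > 26000 nM in this assay, at which 2 of the 2 values shown sit, records. Going by the values given here, the only measured step, a step that the two limits leave unreadable from compound 1 to compound 2, therefore cannot be read in either direction or size.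

Compound 3, `CCOC(=O)CCCCCOc1cccc(CN(C(=O)c2ccc(-c3ccc4[nH]ccc4c3)cc2)C(C)C)c1`, is still to be measured in this assay. It differs from compound 2 by 1H-indol-5-yl in place of 3-(5-methyl-1,3,4-oxadiazol-2-yl)phenyl on an aromatic carbon. Among the compounds with values here, no measured step bears on this change, and the one step available, a step that the two limits leave unreadable from compound 1 to compound 2, tells nothing about how far a change on this aromatic carbon can move the read-out. The expectation for compound 3 can rest only on the fact that every value shown sits at the limit, as the limit of > 26000 nM in this assay, at which 2 of the 2 values shown sit, states, so no step beyond the scatter is expected in this assay and the step that the limit leaves unreadable from compound 2 to compound 3 is an estimate of no readable change. Compound 3 is accordingly expected at about 40000 nM, in the range 13000 nM to 120000 nM, most likely reported again only as a limit.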

Compound 3, half-maximal effective concentration: > 26000 nM
Compound 3 gave a limit, no number; the forecaster's own chance of this, stated with the estimate: 80%; the middle value lies beyond the limit too.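

Compound 3 gives only a limit in this assay, so the steps among compound 1, compound 2 and compound 3 cannot be read in direction or size: the limit of > 26000 nM in this assay, at which 3 of the 3 values shown sit. The compounds shown leave open what concentration in this assay would give the half-maximal effect for any of the three.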